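This account rests on a few compounds, and the source may have more. Where it says the series, first, only, none or still open, it means among the compounds named here.

Measured so far:
- compound 1 `COc1ccc(N2C(=O)COc3ccc(-c4cnc(OC)c(NS(=O)(=O)c5ccc(F)cc5)c4)cc32)cc1`: 1350 nM
- compound 2 `O=C1COc2ccc(-c3cnc(Cl)c(NS(=O)(=O)c4ccc(F)cc4)c3)cc2N1C1CCCCC1`: 37900 nM
- compound 3 `O=C1COc2ccc(-c3cnc4ccccc4c3)cc2N1C1CCCCC1`: limit, > 40000 nM

In a functional assay on A549 cells (Homo sapiens) for antiproliferative activity, read by MTT assay, with a stated time of 72 h (a lower number here means a stronger inhibitor, a higher number a weaker inhibitor), compound 1 gives 1350 nM, the lowest of the two numbers recorded. For the measured compounds named here, compound 2 gives 37900 nM in this assay, a gap beyond the scatter, but it differs from compound 1 in more than one place, so the two values show only that compound 2 is the weaker of the pair. For compound 3 the reading in this assay is a limit, > 40000 nM, and not a number.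

The next compound is compound 4 `COc1ncc(-c2ccc3c(c2)N(C(C)C)C(=O)CO3)cc1NS(=O)(=O)c1ccc(F)cc1`. It differs from compound 1 in one place:
isopropyl in place of 4-methoxyphenyl on an amide-type nitrogen in a ring
Both compound 2 and compound 3 carry a cyclohexyl on the ring amide nitrogen in place of the 4-methoxyphenyl of compound 1, and both are weaker, but neither is a single-point step, so the size of the effect of this change alone is not known from the data. An increase in the number in this assay beyond the scatter is expected when moving to the isopropyl, smaller than the gap to compound 2. Compound 4 is estimated at 5000 nM in this assay, within 1500 nM to 20000 nM, a step of a 3.7-fold higher number from compound 1 to compound 4 (0.57 log units; beyond the scatter).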

Compound 4, half-maximal inhibitory concentration: 4920 nM
Compound 4: middle estimate off by 1.0-fold (0.01 log units), on the high side, within the range that was stated.
By their numbers in this assay, from the lowest: compound 1; then compound 4; then compound 2. At a limit, above all of these: compound 3.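

In this assay, for the compounds shown here, isopropyl in place of 4-methoxyphenyl on the amide-type nitrogen in a ring gives a 3.6-fold higher number from compound 1 to compound 4 (0.56 log units; beyond the scatter), the first change at this position whose effect can be read on its own. The step is beyond the scatter but modest: with 3 heavy atoms and no ring in place of 8 heavy atoms and a six-membered aromatic ring, the substituent shrinks considerably, yet compound 4 still gives a measured number in this assay. An aromatic ring at this position is therefore not required for antiproliferative activity on this core, although compound 1, which carries one, has the lower number of the pair, and nothing measured here bears on why the step has this size.

From the compounds shown here alone, it remains open whether the difference follows the aromatic ring or simply the size of the group, which a plain phenyl, a methyl or a longer chain such as n-butyl on this nitrogen would help separate. Also open, going by these compounds, is how a cyclohexyl behaves on the core of compound 1 with everything else unchanged, and whether an amine or a carboxylic acid on the aryl ring is tolerated.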